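Expected Effect of a Methyl Group on Compound 2

The source may hold more compounds than are shown below. What is called first, only, known or untested is meant among the compounds shown, and "the series" means these compounds.

Measured so far:
Compound 1 `Cc1ccnc(/C(N)=N/NC(=S)N2CCOCC2)c1` gives 87.4% in a functional assay on A-375 cells (Homo sapiens) for cytotoxicity, read by MTT assay, with a stated time of 72 h, tested at 30 uM; on this read-out lower numbers stand for less inhibition of growth and higher numbers for more inhibition of growth at the one concentration tested.
Compound 2 `N/C(=N\NC(=S)N1CCCC1)c1ccccn1` gives 86% in this assay.

In this assay compound 2 and compound 1 lie within the scatter of each other, so neither stands apart. Compound 3 `Cc1ccnc(/C(N)=N/NC(=S)N2CCCC2)c1` differs from compound 2 by methyl in place of hydrogen on an aromatic carbon. Compound 1 already carries this methyl, and in this assay compound 1 gives 87.4%, so the expected step is a number 1 percentage points higher from compound 2 to compound 3 (within the scatter), none beyond the scatter. Compound 3 is therefore estimated at 87%, between 78% and 94%.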

Compound 3, percent growth inhibition at one concentration: 87.9%
The estimate for compound 3 lay 0.9 percentage points below the measured number; low and high end bracket the measured number.
By their numbers in this assay, from the lowest: compounds 2, 1 and 3 (each within the scatter of the next).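

In this assay, methyl in place of hydrogen on the aromatic carbon opposite the ring nitrogen gives a number 1.9 percentage points higher from compound 2 to compound 3 (within the scatter), so this position accepts the methyl with pyrrolidin-1-yl on the thiocarbonyl carbon as well as with morpholin-4-yl. With the methyl in place, pyrrolidin-1-yl in place of morpholin-4-yl gives a number 0.5 percentage points higher from compound 1 to compound 3 (within the scatter), so these two groups cannot be told apart here. Nothing measured here bears on a cause for these results. On these data alone, whether an ethyl group, a methoxy group or an amine on this carbon would also stay within the scatter remains open. As far as these compounds go, whether these compounds differ at lower concentrations also remains open.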